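The compounds below may be only part of what the source reports. "The series", "measured", "known", "first", "only" and "open" are said of these compounds alone.

Measured compounds:
Compound 1 `Fc1cccc(N2CCN(CCCCOc3ccc4c(c3)CCC4)CC2)c1` gives 15% in a functional assay on the whole organism for inhibition, with Mus musculus as the target, at a dose of 25 mg/kg by the oral route; a higher number here means more inhibition at the dose given (going by the name of the read-out), a lower number less inhibition.
Compound 2 `COc1ccc(N2CCN(CCCOc3ccc4c(c3)CCC4)CC2)cc1` gives 60% in this assay.

Of the two numbers in hand, compound 1 stands lowest. Among the measured compounds shown here, its nearest neighbour, compound 2, differs from it in more than one place, so no single step connects them; the two values show compound 2 higher by a margin beyond the usual scatter, and nothing more can be read from that pair.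

Compound 3 `O=[N+]([O-])c1ccc(N2CCN(CCCCOc3ccc4c(c3)CCC4)CC2)cc1` has not yet been measured in this assay. It follows from compound 1 by one change: 4-nitrophenyl in place of 3-fluorophenyl on an amine nitrogen in a ring. For the measured compounds named here, no measured pair shows this change, so its effect can only be guessed. Given that compound 1 sits at 15% and compound 2 at 60%, a modest rise is expected, with the step of a number 20 percentage points higher from compound 1 to compound 3 (beyond the scatter) estimated as upward but uncertain. For compound 3 the estimated value is 35%, expected to lie between 10% and 65%.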

Compound 3, a percentage reported as inhibition, in the whole organism at one dose (the size of the read-out at that dose, not a potency): 0%
For compound 3 the middle estimate is 35 percentage points above the measured one, outside the stated range (below it).
By their numbers in this assay, from the lowest: compound 3; then compound 1; then compound 2.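

Among the compounds shown here, at the aryl group on the amine nitrogen of the ring, the change to 4-nitrophenyl in place of 3-fluorophenyl gives the first single-place comparison in this assay, a number 15 percentage points lower from compound 1 to compound 3 (beyond the scatter). This shows that the read-out responds to the group at this position even with the rest of compound 1 kept, and that this exchange, which brings in two hydrogen-bond acceptors, lowers it rather than raises it. Nothing at hand accounts for the direction of this step.

The substituent and its place on the phenyl ring change together in this single step, so their contributions cannot be separated. On these data alone, how a 4-fluorophenyl, a 3-nitrophenyl or an unsubstituted phenyl would read at this nitrogen remains open.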